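This account rests on a few compounds, and the source may have more. Where it says the series, first, only, none or still open, it means among the compounds named here.

Measured compounds:
compound 1 `Cc1cccc(NC(=O)C2(C(=O)Nc3ccc(Nc4ncc(F)c(-c5cc(F)c6nc(C)n(C(C)C)c6c5)n4)cc3)CC2)c1` – 179 nM
compound 2 `Cc1nc2c(F)cc(-c3nc(Nc4ccc(NC(=O)C5(C(=O)Nc6ccc(Br)cc6)CC5)cc4)ncc3F)cc2n1C(C)C` – 597 nM

In a functional assay on HeLa cells (Homo sapiens) for antiproliferative activity, read by CCK-8 assay, with a stated time of 72 h (a higher number here means a weaker inhibitor, a lower number a stronger inhibitor), compound 2 stands at the higher of the two numbers; its nearest neighbour, compound 1, differs from it by a 3.3-fold higher number from compound 1 to compound 2 (0.52 log units; beyond the scatter), a step that arises from 4-bromophenyl in place of 3-methylphenyl on an amide-type nitrogen. Compound 3 `Cc1nc2c(F)cc(-c3nc(Nc4ccc(NC(=O)C5(C(=O)Nc6cccc(F)c6)CC5)cc4)ncc3F)cc2n1C(C)C` has not yet been measured. It differs from compound 2 by 3-fluorophenyl in place of 4-bromophenyl on an amide-type nitrogen. Among the measured compounds shown here, no measured step covers this exact exchange; the only step that bears on it is a 3.3-fold higher number from compound 1 to compound 2 (0.52 log units; beyond the scatter), which shows that the aryl group on this amide-type nitrogen can move the number by a modest amount. Since 3-fluorophenyl returns to a substituent pattern closer to the 3-methylphenyl of compound 1, a modest lowering, a 2.0-fold lower number from compound 2 to compound 3 (0.30 log units; within the scatter), is expected. Compound 3 is therefore estimated at 300 nM, with a range of 120 nM to 750 nM.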

Compound 3, half-maximal inhibitory concentration: 106 nM
The estimate for compound 3 lay 2.8-fold (0.45 log units) above the measured number; measured number below the stated range.
By their numbers in this assay, from the lowest: compounds 3 and 1 (each within the scatter of the next); then compound 2.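

In this assay, the aryl group on the amide-type nitrogen now gives a larger swing, with 3-fluorophenyl in place of 4-bromophenyl producing a 5.6-fold lower number from compound 2 to compound 3 (0.75 log units; beyond the scatter) and leaving compound 2 apart from the other two compounds. Fluoro in place of methyl on an aromatic carbon gives a 1.7-fold lower number from compound 1 to compound 3 (0.23 log units; within the scatter), so 3-fluorophenyl and 3-methylphenyl cannot be told apart at this position in this assay. No measurement shown here accounts for the separate standing of 4-bromophenyl.

Because the step from compound 2 to compound 3 changes both the halogen and its place on the ring, these compounds cannot show which of the two matters; 3-bromophenyl and 4-fluorophenyl would separate them. Going by these compounds, it also remains open how this position would respond to a group of another kind, such as an amine or a carboxylic acid on the phenyl ring.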